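Heteroaryl swap at the carbon bearing the ring substituent

The source may hold more compounds than are shown below. What is called first, only, known or untested is meant among the compounds shown, and "the series" means these compounds.

Measured compounds:
- compound 1, `CCn1nc(-c2cccnc2)c2ccccc2c1=O`: 87%
- compound 2, `CCn1nc(-n2ccnc2)c2ccccc2c1=O`: 53%
- compound 3, `CCn1nc(-n2cncn2)c2ccccc2c1=O`: 0%

In an assay on isolated protein (Oryctolagus cuniculus) with Thromboxane-A synthase (Homo sapiens) as the target, tested at 1 uM (a lower number here means less inhibition, a higher number more inhibition at the concentration tested (going by the name of the read-out)), compound 3 gives 0%, the lowest of the three numbers. Its nearest neighbour is compound 2, with a number 53 percentage points lower from compound 2 to compound 3 (beyond the scatter) separating them; the furthest is compound 1, with a number 87 percentage points lower from compound 1 to compound 3 (beyond the scatter). Both steps are beyond the scatter, and both remove the pyridin-3-yl or 1H-imidazol-1-yl group in favour of 1H-1,2,4-triazol-1-yl, each time with a large fall.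

Compound 4, `CCn1nc(-c2nccs2)c2ccccc2c1=O`, has not yet been measured in this assay. It differs from compound 3 as follows: 1,3-thiazol-2-yl in place of 1H-1,2,4-triazol-1-yl on an aromatic carbon

For the measured compounds named here, the steps that bear on it are the two that end at compound 3, since compound 4 again replaces the 1H-1,2,4-triazol-1-yl group with a different five-membered ring. Read in reverse, they suggest a rise, but neither involves 1,3-thiazol-2-yl, and no step among the measured compounds tells how large that rise should be. A step upward from compound 3 to compound 4 is therefore expected, a number 30 percentage points higher from compound 3 to compound 4 (beyond the scatter), with wide uncertainty. For compound 4 the estimate in this assay is 30%, in the range 5% to 65%.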

Compound 4, a percentage reported as inhibition, at one concentration (the size of the read-out at that concentration, not a potency): 4%
The estimate for compound 4 lay 26 percentage points above the measured number, and the stated range ends above it.
By their numbers in this assay, from the lowest: compounds 3 and 4 (each within the scatter of the next); then compound 2; then compound 1.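

In this assay, 1,3-thiazol-2-yl in place of 1H-1,2,4-triazol-1-yl gives a number 4 percentage points higher from compound 3 to compound 4 (within the scatter), so the near-absence of inhibition at this position is not confined to the triazole. Against the other two groups, the same ring gives a number 49 percentage points lower from compound 2 to compound 4 (beyond the scatter) and a number 83 percentage points lower from compound 1 to compound 4 (beyond the scatter), which shows that a ring joined through carbon does not by itself hold the number up, since compound 1 and compound 4 are both joined this way yet lie far apart, and that a five-membered ring does not by itself set the level, since compound 2 stands well clear of compound 3 and compound 4. No measurement shown accounts for these differences between the rings.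

Still open, on these data alone, is whether the high number of compound 1 depends on the pyridin-3-yl group specifically, which pyridin-4-yl, pyridin-2-yl or a plain phenyl ring at the same carbon would test. Also open, as far as these compounds go, is how a small amine or a carboxylic acid on that ring, or a longer chain in place of the ethyl group, would change the read-out.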